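Amino for Fluoro on the Hydroxyphenyl Hydrazone

A few compounds are considered here, and "the series" means these few. Any claim that something is new, unique, unknown or untested is made for them only; others in the source may bear on it.

Measured in a functional assay on MCF7 cells (Homo sapiens) for antiproliferative activity, read by MTT assay, with a stated time of 72 h; a higher number here means a weaker inhibitor, a lower number a stronger inhibitor:
Compound 1 `C/C(=N\NC(=O)c1cccc(S(=O)(=O)N2CCOCC2)c1)c1ccccc1O` gives 5400 nM.
Compound 2 `C/C(=N\NC(=O)c1cccc(S(=O)(=O)N2CCOCC2)c1)c1ccc(O)cc1` reaches only > 100000 nM, which is a limit of the assay and not a number.
Compound 3 `C/C(=N\NC(=O)c1cccc(S(=O)(=O)N2CCOCC2)c1)c1cc(F)ccc1O` gives 6650 nM.

Compound 3 sits near compound 1: the step of a 1.2-fold higher number from compound 1 to compound 3 (0.09 log units; within the scatter) stays inside the usual scatter. Compound 2 sits at a limit, (the limit of > 100000 nM in this assay, at which 1 of the 3 values shown sits), so the steps of an at least 18-fold higher number from compound 1 to compound 2 (1.26 log units; beyond the scatter) and an at least 15-fold lower number from compound 2 to compound 3 (1.17 log units; beyond the scatter) can only be given as lower bounds, yet both are large.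

Compound 4 `C/C(=N\NC(=O)c1cccc(S(=O)(=O)N2CCOCC2)c1)c1cccc(N)c1O` differs from compound 3 at one place: 3-amino-2-hydroxyphenyl in place of 5-fluoro-2-hydroxyphenyl on a carbon with a double bond to nitrogen. The hydroxyl stays where it is in compound 1 and compound 3, the fluorine goes, and an amino group comes in. Among the compounds with values here, the only step that touches this region without moving the hydroxyl is a 1.2-fold higher number from compound 1 to compound 3 (0.09 log units; within the scatter), which was within the scatter; the large steps to and from compound 2 concern the moved hydroxyl, which compound 4 does not share. Within the data shown here, no measured step shows an amino group. The expectation for compound 4 in this assay is therefore a step of a 1.1-fold lower number from compound 3 to compound 4 (0.04 log units; within the scatter), not beyond the scatter. Compound 4 is estimated at 6000 nM, between 2500 nM and 15000 nM.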

Compound 4, half-maximal inhibitory concentration: 1010 nM
For compound 4 the middle estimate is 5.9-fold (0.77 log units) above the measured one; the whole stated range lies above it.
By their numbers in this assay, from the lowest: compound 4; then compounds 1 and 3 (each within the scatter of the next). At a limit, above all of these: compound 2.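

Within the data shown here, until now, the only change on this ring that kept the hydroxyl in place was the fluoro of compound 3, and it stayed within the scatter. An amino group does more: the steps of a 5.3-fold lower number from compound 1 to compound 4 (0.73 log units; beyond the scatter) and a 6.6-fold lower number from compound 3 to compound 4 (0.82 log units; beyond the scatter) are both modest but beyond the scatter, which makes compound 4 the strongest of the four in this assay and shows that this group can lower the number as well as leave it unchanged. Compound 2 carries a limit and not a number, and the step of an at least 99-fold lower number from compound 2 to compound 4 (1.99 log units; beyond the scatter) is only a lower bound: the limit of > 100000 nM in this assay, at which 1 of the 4 values shown sits.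

The compounds shown do not separate the effect of having an amino group from the effect of where it sits, as none carries one in the place the fluorine holds in compound 3. They also leave open whether a dimethylamino or acetamido group there would lower the number further or lose the gain.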